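Swapping the Aryl Ring on a Potassium Channel Opener

This account rests on a few compounds, and the source may have more. Where it says the series, first, only, none or still open, it means among the compounds named here.

Compound 2 `Cc1cc(NC(=O)Cn2nnc(-c3ccc(F)cc3)n2)n(C2CCCCC2)n1` holds the higher of two results in an assay on HEK293 cells for activation of Kir3.1/Kir3.2 (Homo sapiens), read by thallium flux; a higher number here means a larger maximal response, a lower number a smaller maximal response: there compound 2 gives 92%, while compound 1 `CC1CC1c1cc(NC(=O)Cn2nnc(-c3ccccc3)n2)n(C2CCCCC2)n1` gives 78%, a gap beyond the usual scatter. Compound 3 `Cc1cc(NC(=O)Cn2nnc(-c3ccc(Cl)c(C)c3)n2)n(C2CCCCC2)n1` has not yet been tested. It differs from compound 2 in one place: 4-chloro-3-methylphenyl in place of 4-fluorophenyl on an aromatic carbon. For the measured compounds named here, no measured pair follows this exact change, so the step from compound 2 to compound 3 in this assay is only an expectation, estimated as a number 4 percentage points lower from compound 2 to compound 3 (within the scatter), most likely none beyond the scatter. Compound 3 is expected to reach about 88% in this assay, within a range from 72% to 104%.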

Compound 3, largest response reached (Emax), in percent of the reference or control that the assay uses: 89%
Compound 3: middle estimate off by 1 percentage points, on the low side; the range from low to high includes it.
By their numbers in this assay, from the lowest: compound 1; then compounds 3 and 2 (each within the scatter of the next).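

Swapping 4-fluorophenyl for 4-chloro-3-methylphenyl on this aromatic carbon gives, in this assay, a number 3 percentage points lower from compound 2 to compound 3 (within the scatter). For the compounds shown here, this is the first step here that isolates this position, and it shows that the maximal response holds when the phenyl ring carries a chlorine and a methyl group instead of a fluorine; compound 1 and compound 2 differ in more than one place and could not show this. Nothing available explains this result. From the compounds shown here alone, whether the response would also hold with an amine or a carboxylic acid on this phenyl ring remains open.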